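Methyl to Trifluoromethyl on the Aryl Ether Oxygen

The source may report more compounds than this note shows. Statements on the series, on what has been measured and on what is new or still open speak of the compounds shown alone.

Compound 1 `Fc1ccc(-n2cc(COc3ccccc3-c3nc4ccccc4s3)nn2)cc1` gives 33300 nM in an ADME assay on MCF-10A cells (Homo sapiens) for cytotoxicity, read by MTT assay, with a stated time of 24 h; a higher number here means a weaker inhibitor, a lower number a stronger inhibitor.
Compound 2 `Brc1ccc(-c2cc(COc3ccccc3-c3nc4ccccc4s3)on2)cc1` gives 29200 nM in this assay.
Compound 3 `COc1ccc(-c2cc(COc3ccccc3-c3nc4ccccc4s3)on2)cc1` gives 34100 nM in this assay.

These three compounds share one core and differ only in the group carried by the outer phenyl ring. Compound 3 sits in the same band as the other two: its nearest neighbour is compound 1 and its farthest is compound 2, and all three numbers lie within the usual scatter of one another. Among the measured compounds shown here, the only single-point step among them, a 1.2-fold higher number from compound 2 to compound 3 (0.07 log units; within the scatter), did not move the number beyond that scatter.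

Compound 4 `FC(F)(F)Oc1ccc(-c2cc(COc3ccccc3-c3nc4ccccc4s3)on2)cc1` differs from compound 3 in one place: trifluoromethyl in place of methyl on an oxygen on an aromatic ring. For the measured compounds named here, no measured step exchanges methyl for trifluoromethyl, so the closest guide is the change at the same ring position, from bromo to methoxy, which stayed within the scatter, together with the fluoro-bearing compound 1 falling into the same band. On that basis, compound 4 is expected to show no step beyond the scatter, so the expected step of a 1.1-fold lower number from compound 3 to compound 4 (0.03 log units; within the scatter) is essentially flat. Compound 4 is therefore estimated at 32000 nM, with a likely range from 15000 nM to 68000 nM in this assay.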

Compound 4, half-maximal inhibitory concentration: 43900 nM
The estimate for compound 4 lay 1.4-fold (0.14 log units) below the measured number; measured number inside the range.
By their numbers in this assay, from the lowest: compounds 2, 1, 3 and 4 (each within the scatter of the next).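

Replacing the methyl on the oxygen with trifluoromethyl, which exchanges one heavy atom for four, gives a 1.3-fold higher number from compound 3 to compound 4 (0.11 log units; within the scatter) in this assay, so this change to the oxygen substituent leaves the number in the same band. Comparing the new group directly with bromo on the aromatic carbon gives a 1.5-fold higher number from compound 2 to compound 4 (0.18 log units; within the scatter), so all three pairs among bromo, methoxy and trifluoromethoxy on the outer phenyl ring now lie within the scatter, and no group in this set stands apart from the others. The data include no measurement that could explain this flat picture.

The compounds shown leave open whether an amine or a carboxylic acid on the outer phenyl ring, or a longer chain on the oxygen in place of methyl or trifluoromethyl, would produce a step beyond the scatter. They also leave open whether these groups would stay just as close together in a test on any other type of cell.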